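Cyanobenzyl position in the imidazole series: first test

The compounds below may be only part of what the source reports. "The series", "measured", "known", "first", "only" and "open" are said of these compounds alone.

Compound 1 `COC(=O)[C@H](CCSC)NC(=O)c1ccc(NCc2cncn2Cc2cccc(C#N)c2)cc1-c1ccccc1` gives > 10 uM in a functional assay on NIH3T3 cells (Mus musculus) (a lower number here means that less compound is needed, a higher number that more compound is needed for the effect), which is a limit of the assay and not a number. Compound 2 `COC(=O)[C@H](CCSC)NC(=O)c1ccc(CN(Cc2c[nH]cn2)Cc2c[nH]cn2)cc1-c1ccccc1C` also sits at a limit, giving > 10 uM in this assay. Compound 3 `CSCC[C@H](NC(=O)c1ccc(NCc2cncn2Cc2cccc(C#N)c2)cc1-c1ccccc1)C(=O)O`, which carries the free acid, likewise gives > 10 uM in this assay, again a limit. Within the data shown here, the one step between compounds that differ in a single place, a step that the two limits leave unreadable from compound 1 to compound 3, therefore cannot be sized, because the limit of > 10 uM in this assay, at which 3 of the 3 values shown sit, removes any readable difference. Compound 1 thus stands only at a limit, and so do the two further values shown.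

Compound 4 `COC(=O)[C@H](CCSC)NC(=O)c1ccc(NCc2cncn2Cc2ccccc2C#N)cc1-c1ccccc1` differs from compound 1 by 2-cyanophenyl in place of 3-cyanophenyl on a saturated chain carbon bound to an aromatic nitrogen. Among the measured compounds shown here, no measured step touches this change: the step from compound 1 to compound 3 concerns the ester and is unreadable in any case, and compound 2 is not linked to the others by a single change. Nothing in the data sets a direction in this assay, so the expectation rests on the limits alone. With every shown value at the limit, compound 4 is expected to remain there too, most likely reported once more as a limit, so that the expected step that the limit leaves unreadable from compound 1 to compound 4 is none beyond the scatter. The estimate for compound 4 is 20 uM, with a range from 5 uM to 80 uM.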

Compound 4, concentration for half-maximal effect: > 10 uM
Compound 4 was reported as a limit; the forecaster's own chance of this, stated with the estimate: 75%; the middle value does not contradict the limit.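

No step can be read for the move from 3-cyanobenzyl to 2-cyanobenzyl between compound 1 and compound 4, because both results are limits of the assay and not numbers: the limit of > 10 uM in this assay, at which 4 of the 4 values shown sit.

The compounds shown leave open which change to the shared core, if any, gives a readable value in this assay.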